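Butyl replaces the 3-amino-2-hydroxypropyl chain on the core

The source may report more compounds than this note shows. Statements on the series, on what has been measured and on what is new or still open speak of the compounds shown alone.

Measured compounds in a functional assay (B cells) with Mus musculus as the target; on this read-out higher numbers stand for an effect only at larger amounts of compound and lower numbers for an effect already at smaller amounts:
compound 1 `[N-]=[N+]=NCC(O)Cn1c(=O)n(C2OC(CO)[C@@H](O)[C@H]2O)c2nc(N)nc(O)c21`: 39 uM
compound 2 `Nc1nc(O)c2c(n1)n(C1OC(CO)[C@@H](O)[C@H]1O)c(=O)n2Cc1ccc(Cl)cc1`: 14 uM
compound 3 `NCC(O)Cn1c(=O)n(C2OC(CO)[C@@H](O)[C@H]2O)c2nc(N)nc(O)c21`: 28 uM

Compound 3 stands second highest of the three numbers; its nearest neighbour is compound 1, a 1.4-fold lower number from compound 1 to compound 3 (0.14 log units; within the scatter), and its furthest is compound 2, a 2.0-fold higher number from compound 2 to compound 3 (0.30 log units; within the scatter), both within the scatter. Compound 4 `CCCCn1c(=O)n(C2OC(CO)[C@@H](O)[C@H]2O)c2nc(N)nc(O)c21` is not yet measured. The change from compound 3 to compound 4 is propyl in place of 2-amino-1-hydroxyethyl on a saturated chain carbon bound to an aromatic nitrogen.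

Among the measured compounds shown here, only one measured step touches the same position and goes beyond the scatter: a 2.8-fold lower number from compound 1 to compound 2 (0.44 log units; beyond the scatter), a modest lowering when a ring group took the place of a chain carrying a hydroxyl and an azide. The step from compound 2 to compound 3 shows that the chain with amino and hydroxyl reads within the scatter of the chlorophenyl case. For the measured compounds named here, no step shows a plain alkyl chain at this position, so the expectation rests on the modest size of the changes seen here. A small lowering of the number is expected for compound 4, a 1.4-fold lower number from compound 3 to compound 4 (0.15 log units; within the scatter), with a range that includes no change beyond the scatter.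

Compound 4 is estimated at 20 uM in this assay, from 8 uM to 50 uM.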

Compound 4, concentration for half-maximal effect: 11 uM
Beside the measured number, compound 4's estimate is 1.8-fold (0.26 log units) above it, within the range that was stated.
By their numbers in this assay, from the lowest: compounds 4, 2, 3 and 1 (each within the scatter of the next, the first and the last beyond it).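

In this assay, butyl in place of the 3-amino-2-hydroxypropyl chain gives a 2.5-fold lower number from compound 3 to compound 4 (0.41 log units; beyond the scatter), and this shows that a plain alkyl chain at this position, on a saturated chain carbon bound to an aromatic nitrogen, can carry a lower number than the chain with amino and hydroxyl. Against the azido chain the change gives a 3.5-fold lower number from compound 1 to compound 4 (0.55 log units; beyond the scatter), also beyond the scatter, while the comparison with the 4-chlorophenyl case gives a 1.3-fold lower number from compound 2 to compound 4 (0.10 log units; within the scatter), within the scatter, so among these compounds an aromatic ring at this position is not required to reach the low end of the series. Nothing available on these compounds gives a reason for these steps.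

The change to butyl takes away the amino and the hydroxyl together, so the compounds shown do not separate the share of each, which a 2-hydroxybutyl or a 3-aminopropyl chain at this position would address. How far the trend runs also stays open, since a longer chain such as hexyl, or a chain ending in a carboxylic acid, has no counterpart among these compounds.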